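A few compounds are considered here, and "the series" means these few. Any claim that something is new, unique, unknown or untested is made for them only; others in the source may bear on it.

Working notes on the series. Going by the values given here, in a functional assay for antagonist activity at transient receptor potential cation channel subfamily V member 1 (Rattus norvegicus) (on this read-out higher numbers stand for weaker inhibition and lower numbers for stronger inhibition), compound 3 `CC(C)(C)c1ccc(NC(=O)c2ccc(-c3ncccc3C(=O)O)cc2)cc1` gives 560 nM, the highest number of the three measured so far. Compound 1 `Cc1cccnc1-c1ccc(C(=O)Nc2ccc(C(C)(C)C)cc2)cc1` gives 9 nM in this assay, and compound 2 `CC(C)(C)c1ccc(NC(=O)c2ccc(-c3ncccc3NS(=O)(=O)c3ccccc3)cc2)cc1` gives 166 nM. Compound 3 thus stands furthest from compound 1 and nearest to compound 2, as the steps of a 62-fold higher number from compound 1 to compound 3 (1.79 log units; beyond the scatter) and a 3.4-fold higher number from compound 2 to compound 3 (0.53 log units; beyond the scatter) show; the step of an 18-fold higher number from compound 1 to compound 2 (1.27 log units; beyond the scatter) places compound 2 between the other two.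

Compound 4 `CC(C)(C)c1ccc(NC(=O)c2ccc(-c3ncccc3-c3nnco3)cc2)cc1` differs from compound 3 by 1,3,4-oxadiazol-2-yl in place of carboxy on an aromatic carbon. Among the compounds with values here, no measured step covers this exchange directly. Within the data shown here, the steps that bear on it are those ending at compound 3: a 62-fold higher number from compound 1 to compound 3 (1.79 log units; beyond the scatter) and a 3.4-fold higher number from compound 2 to compound 3 (0.53 log units; beyond the scatter), both large to modest, and both arriving at the carboxy that compound 4 gives up. Among the measured compounds shown here, the group that enters is aromatic and carries no hydrogen-bond donor, so the expectation is a move back toward compounds 1 and 2 rather than further up, though with no direct precedent the size is uncertain.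

Compound 4 is therefore expected to give about 200 nM in this assay, with a plausible range from 50 nM to 900 nM. That expectation amounts to a 2.8-fold lower number from compound 3 to compound 4 (0.45 log units; beyond the scatter).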

Compound 4, half-maximal inhibitory concentration: 59 nM
Estimate against measurement, compound 4: 3.4-fold (0.53 log units) above; the range from low to high includes it.
By their numbers in this assay, from the lowest: compound 1; then compound 4; then compound 2; then compound 3.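

In this assay, the step of a 9.5-fold lower number from compound 3 to compound 4 (0.98 log units; beyond the scatter) shows that this position, on an aromatic carbon ortho to a large group, can carry a five-membered aromatic ring with 3 hetero atoms and still give a lower number than carboxy does. Going by these compounds alone, the same group also improves on (phenylsulfonyl)amino, with a 2.8-fold lower number from compound 2 to compound 4 (0.45 log units; beyond the scatter), so it is the first exchange here to recover much of what the larger replacements of methyl lose, though the step of a 6.6-fold higher number from compound 1 to compound 4 (0.82 log units; beyond the scatter) shows that the small methyl still gives the lowest number of the four. Nothing measured on these compounds accounts for this order, so the result stands as an observation only.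

The compounds shown leave open whether the gain over carboxy goes with the loss of the hydrogen-bond donor, with the added ring, or with the hydrogen-bond acceptors that enter, since these all change together in this one exchange. A methyl ester, a primary amide, an unsubstituted phenyl or a 1,2,4-oxadiazole at the same position would begin to separate these features, and a chloro or ethyl group would show how narrowly the low number of compound 1 depends on methyl.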